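The source may report more compounds than this note shows. Statements on the series, on what has been measured and on what is new or still open speak of the compounds shown alone.

Compound 2 `COc1ccc(CNCc2c(OC)cc(Oc3cccc(Nc4ccccc4)c3)cc2OC)cc1` is the lower of the two numbers obtained in a functional assay on DLD-1 cells (Homo sapiens) for inhibition, read by MTT assay, with a stated time of 72 h (on this read-out lower numbers stand for stronger inhibition and higher numbers for weaker inhibition), where compound 2 gives 1910 nM. Compound 3 `COc1ccc([C@@H](C)NCc2c(OC)cc(Oc3cccc(Nc4ccccc4)c3)c(OC)c2OC)cc1` gives 3500 nM in this assay, which sits within the usual scatter of the value of compound 2. Compound 1 `COc1cc(Oc2cccc(Nc3ccccc3)c2)cc(OC)c1CNC(C)C` returns only a limit in this assay, > 20000 nM. Within the data shown here, the one measured step that bears on the next compound is an at least 10-fold lower number from compound 1 to compound 2 (1.01 log units; beyond the scatter), which reads 4-methoxybenzyl in place of isopropyl on an amine nitrogen. Compound 4 `COc1cc(Oc2cccc(Nc3ccccc3)c2)cc(OC)c1CN(C)C` differs from compound 2 by dimethylamino in place of (4-methoxybenzyl)amino on a saturated chain carbon bound to an aromatic carbon. Since that change removes the 4-methoxybenzyl whose arrival produced the large drop an at least 10-fold lower number from compound 1 to compound 2 (1.01 log units; beyond the scatter), a large rise toward the limit of > 20000 nM in this assay, at which 1 of the 3 values shown sits, is expected, as a 7.9-fold higher number from compound 2 to compound 4 (0.90 log units; beyond the scatter). Compound 4 is therefore estimated at 15000 nM, in the range 4000 nM to 50000 nM.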

Compound 4, half-maximal inhibitory concentration: > 20000 nM
Compound 4 was reported as a limit; the forecaster's own chance of this, stated with the estimate: 55%; at least 1.3-fold (0.12 log units) between middle value and limit.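

Setting dimethylamino in place of (4-methoxybenzyl)amino on this saturated chain carbon gives an at least 10-fold higher number from compound 2 to compound 4 (1.01 log units; beyond the scatter) in this assay, so a second small amino group, after isopropylamino, also falls well short of (4-methoxybenzyl)amino. The step between dimethylamino and isopropylamino cannot be read, so these two groups cannot be ranked. Compound 4 is reported only as a limit, as compound 1 is: the limit of > 20000 nM in this assay, at which 2 of the 4 values shown sit.

On these data alone, it remains open whether the ring or its methoxy group accounts for the difference, which plain benzylamino would address. Phenethylamino would show how a longer chain to the ring fares.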